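A Five-Membered Ring Replaces the Methoxyphenyl

The compounds below may be only part of what the source reports. "The series", "measured", "known", "first", "only" and "open" are said of these compounds alone.

Compound 3 `COc1cccc(/C=C/C(=O)/C=C/c2ccc(OCc3cn(CCOc4cc(=O)oc5ccccc45)nn3)c(OC)c2)c1` belongs to a set of three compounds that share one core and differ only in the group on a double-bonded chain carbon bound to a double-bonded chain carbon. In a functional assay on COLO 205 cells (Homo sapiens) for inhibition, read by sulforhodamine B assay, with a stated time of 48 h, tested at 50 uM (a higher number here means more inhibition of growth at the concentration tested, a lower number less inhibition of growth), compound 3 gives 69%, the second highest of the three numbers. Compound 1 `COc1ccccc1/C=C/C(=O)/C=C/c1ccc(OCc2cn(CCOc3cc(=O)oc4ccccc34)nn2)c(OC)c1` gives 67%, which lies within the scatter of compound 3, while compound 2 `COc1cc(/C=C/C(=O)/C=C/c2cccc3ccccc23)ccc1OCc1cn(CCOc2cc(=O)oc3ccccc23)nn1` gives 85%, a gap beyond the scatter.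

Compound 4 `COc1cc(/C=C/C(=O)/C=C/c2ccco2)ccc1OCc1cn(CCOc2cc(=O)oc3ccccc23)nn1` has not yet been measured. It differs from compound 3 in one place: furan-2-yl in place of 3-methoxyphenyl on a double-bonded chain carbon bound to a double-bonded chain carbon.

Among the compounds with values here, two measured steps concern the same place. a number 2 percentage points higher from compound 1 to compound 3 (within the scatter). a number 16 percentage points lower from compound 2 to compound 3 (beyond the scatter). Within the data shown here, neither involves furan-2-yl, so no measured step speaks directly to this change; the only step beyond the scatter ran between naphthalen-1-yl and 3-methoxyphenyl. The estimate for compound 4 is therefore a modest step of a number 7 percentage points lower from compound 3 to compound 4 (within the scatter), expected to stay near the scatter. Compound 4 is expected to give 62%, with a range from 45% to 80%.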

Compound 4, percent growth inhibition at one concentration: 68%
Compound 4: middle estimate off by 6 percentage points, on the low side, and the stated range covers the measured number.
By their numbers in this assay, from the lowest: compounds 1, 4 and 3 (each within the scatter of the next); then compound 2.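

In this assay, swapping a six-membered methoxyphenyl ring for the five-membered furan-2-yl ring at this position changes little: the data show a number 1 percentage points lower from compound 3 to compound 4 (within the scatter) and a number 1 percentage points higher from compound 1 to compound 4 (within the scatter). Naphthalen-1-yl alone stands apart, with a number 17 percentage points lower from compound 2 to compound 4 (beyond the scatter), so a five-membered aromatic ring on this double-bonded chain carbon fits with the two methoxyphenyl groups, and only compound 2 separates from the rest. Nothing measured here accounts for this result.

The compounds shown leave open whether a group without an aromatic ring, such as a longer carbon chain, an amine or a carboxylic acid, would hold the number at this level. They also leave open whether thiophen-2-yl, another five-membered aromatic ring, would sit with furan-2-yl.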